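The source may hold more compounds than are shown below. What is called first, only, known or untested is meant among the compounds shown, and "the series" means these compounds.

Going by the values given here, in a functional assay on HeLa cells (Homo sapiens) for antiproliferative activity, read by MTT assay, with a stated time of 48 h (a lower number here means a stronger inhibitor, a higher number a weaker inhibitor), only two related compounds have results so far. Compound 1 `Fc1ccc(CSc2nnc(-c3cnccn3)s2)cc1` reads > 50000 nM, which is a limit of the assay and not a number. Among the compounds with values here, compound 2 `Fc1ccc(CSc2nnc(-c3cnccn3)n2-c2ccccc2)cc1` gives 7300 nM, the only true number available, so it has no second number to be ranked against.

Compound 3 `Fc1cccc(F)c1CSc1nnc(-c2cnccn2)n1-c1ccccc1` keeps the core of compound 2 and differs in one place, with 2,6-difluorophenyl in place of 4-fluorophenyl on a saturated chain carbon bound to a sulfur. Within the data shown here, no measured pair shows what this kind of swap does in this assay. The expectation therefore stays close to compound 2 at 7300 nM, with no shift beyond the usual scatter and no favoured direction. The expected change is a 1.2-fold lower number from compound 2 to compound 3 (0.09 log units; within the scatter). The estimate for compound 3 is 6000 nM, with an expected range from 1800 nM to 22000 nM.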

Compound 3, half-maximal inhibitory concentration: > 50000 nM
Compound 3: only a limit was reported; the forecaster's own chance of this, stated with the estimate: 8%; at least 8.3-fold (0.92 log units) between middle value and limit.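

In this assay, this place on the molecule proves sensitive: 2,6-difluorophenyl in place of 4-fluorophenyl on a saturated chain carbon bound to a sulfur gives an at least 6.8-fold higher number from compound 2 to compound 3 (0.83 log units; beyond the scatter). The earlier compounds shown here gave no view of this change, and here one added fluorine together with a changed fluorine pattern is enough to take away the measurable activity of compound 2. The reading for compound 3 is a limit of the assay and not a number, so the full size of the step stays unknown: the limit of > 50000 nM in this assay, at which 2 of the 3 values shown sit.

These compounds cannot separate the effect of the second fluorine from the effect of where the fluorines sit. Going by these compounds, how a plain benzyl group, or a longer chain ending in an amine, would read at this place also remains open.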